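This account rests on a few compounds, and the source may have more. Where it says the series, first, only, none or still open, it means among the compounds named here.

In a functional assay on HeLa cells (Homo sapiens) for antiproliferative activity, read by MTT assay, with a stated time of 48 h (on this read-out higher numbers stand for weaker inhibition and lower numbers for stronger inhibition), compound 1 (`COc1cc(CNC(=O)CCCCCCC(C)C)ccc1OCCCCOc1ccc(C(N)=S)cc1`) gives 40700 nM and compound 2 (`COc1cc(CNC(=O)CCCC/C=C/C(C)C)ccc1OCCCCCOc1ccc(C(N)=S)cc1`) gives 46400 nM. These two values lie within the usual scatter of each other, so the numbers shown do not separate compound 2 from compound 1. Compound 3 (`COc1cc(CNC(=O)CCCCCCC(C)C)ccc1OCCCCCOc1ccc(C(N)=S)cc1`) has not been measured yet. It differs from compound 2 in one place: isopentyl in place of 3-methylbut-1-en-1-yl on a saturated chain carbon, four bonds along the chain from a carbonyl carbon. Put simply, isopentyl stands in place of 3-methylbut-1-en-1-yl on a saturated chain carbon, four bonds along the chain from a carbonyl carbon. Among the measured compounds shown here, no measured pair shows this change on its own, so the size of the step cannot be read from the data. In this assay, for the measured compounds named here, no step beyond the scatter is expected in either direction, with compound 1 at 40700 nM and compound 2 at 46400 nM as the only guides. The expected step is a 1.1-fold lower number from compound 2 to compound 3 (0.03 log units; within the scatter), within the scatter. For compound 3, the estimated value is 43000 nM, with an expected range from 22000 nM to 85000 nM.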

Compound 3, half-maximal inhibitory concentration: > 50000 nM
Compound 3 gave a limit, no number (the forecaster's own chance of this, stated with the estimate: 10%); at least 1.1-fold (0.06 log units) between middle value and limit.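

In this assay compound 3 gave a limit of the assay and not a number: the limit of > 50000 nM in this assay, at which 1 of the 3 values shown sits. Putting isopentyl in place of 3-methylbut-1-en-1-yl gives an at least 1.0-fold higher number from compound 2 to compound 3 (0.03 log units; that floor lies within the scatter), so losing the double bond at this place brought no stronger inhibition, though the true size of the step stays hidden. The other one-place change, a group of 11 heavy atoms in place of a group of 10 heavy atoms on a saturated chain carbon, four bonds along the chain from an oxygen on an aromatic ring, gives an at least 1.2-fold higher number from compound 1 to compound 3 (0.08 log units; that floor lies within the scatter), which likewise shows no stronger inhibition.

From the compounds shown here alone, how far compound 3 lies past its limit remains unknown. Also open, going by these compounds, is what a longer chain or an amine in place of isopentyl would do in this assay.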